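This account rests on a few compounds, and the source may have more. Where it says the series, first, only, none or still open, it means among the compounds named here.

Working notes on the cytotoxicity series. Compound 1 `Oc1ccc(-c2nc3cc(C(F)(F)F)ccc3[nH]2)cc1` carries a hydroxy on the aromatic carbon para to the large group; in an ADME assay on MDBK cells (Bos taurus) for cytotoxicity, read by MTT assay, with a stated time of 96 h (on this read-out lower numbers stand for higher toxicity in this test and higher numbers for lower toxicity in this test), compound 1 gives 51000 nM, the highest of the two numbers recorded so far. Compound 2 `O=C(CN1CCCC1)Nc1ccc(-c2nc3cc(Cl)c(Cl)cc3[nH]2)cc1` differs from it in more than one place and is not a single-step neighbour; in this assay compound 2 gives 16000 nM, a number lower than that of compound 1 by more than the usual scatter.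

Compound 3 `CCN(CC)CC(=O)Nc1ccc(-c2nc3cc(C(F)(F)F)ccc3[nH]2)cc1` is the next compound due for measurement. Relative to compound 1 the change is (((diethylamino)methyl)carbonyl)amino in place of hydroxy on an aromatic carbon. Within the data shown here, no measured pair isolates this change, so the expected size of the step rests on the two values above only. Compound 2, which also bears an amino-acetamide on the same ring position, sits at 16000 nM, which suggests the direction of the step in this assay is more likely downward than upward. The estimate for compound 3 is a moderate downward step, a 2.0-fold lower number from compound 1 to compound 3 (0.31 log units; beyond the scatter), expected to bring compound 3 to about 25000 nM, within a range of 10000 nM to 60000 nM.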

Compound 3, half-maximal cytotoxic concentration: 13000 nM
Beside the measured number, compound 3's estimate is 1.9-fold (0.28 log units) above it; low and high end bracket the measured number.
By their numbers in this assay, from the lowest: compounds 3 and 2 (each within the scatter of the next); then compound 1.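

Among these compounds, this is the first step that can be read across a single place. In this assay, (((diethylamino)methyl)carbonyl)amino in place of hydroxy on an aromatic carbon, para to a large group, gives a 3.9-fold lower number from compound 1 to compound 3 (0.59 log units; beyond the scatter), so the number does respond to the group held at this position, though the step is only modest. The change takes 1 heavy atom out and puts 9 heavy atoms in, keeps 1 hydrogen-bond donor and goes from 1 to 2 hydrogen-bond acceptors, so several features move together in this one step and nothing measured on hand tells them apart or accounts for the lower number.

Still open, from the compounds shown here alone, is whether the step belongs to the carbonylamino link or to the diethylamino part, which a plain amino group or an acetylamino group in this place would help to separate. Equally open, going by these compounds, is how the number responds to a longer chain between the carbonyl and the amine, to a morpholine in place of diethylamino, or to a carboxylic acid at this position.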